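This account rests on a few compounds, and the source may have more. Where it says the series, first, only, none or still open, it means among the compounds named here.

Of the compounds shown here, three have been measured in an ADME assay on BEAS-2B cells (Homo sapiens) for cytotoxicity, read by MTT assay, with a stated time of 72 h (a higher number here means a weaker inhibitor of growth, a lower number a stronger inhibitor of growth), and a fourth awaits its number. Compound 1 `CSc1ccc(CNc2nc(SC)nc3ncccc23)cc1` gives 600 nM in this assay. Compound 2 `COc1ccc(CNc2nc(SC)nc3ncccc23)cc1` gives 58500 nM in this assay. Compound 3 `COc1ccc(CNc2nc(SC)nc3ccccc23)cc1` gives 21700 nM in this assay. Compound 2 and compound 1 share a core and differ only in one group: methylsulfanyl in place of methoxy on an aromatic carbon This change made a step of a 98-fold lower number from compound 2 to compound 1 (1.99 log units; beyond the scatter), so compound 1 inhibits growth far more strongly than compound 2.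

Compound 3 carries a different core from compound 2; the difference between the two cores is not broken down here. The unmeasured compound 4 `CSc1ccc(CNc2nc(SC)nc3ccccc23)cc1` stands to compound 3 as compound 1 stands to compound 2: methylsulfanyl in place of methoxy on an aromatic carbon The place of the change is described in the same words for both pairs, so this is the same change made on a second core.

Going by the values given here, only one measured example of this change exists, and nothing shows whether the second core responds in the same way, so the expectation rests on compound 2 and compound 1 alone, because of a 98-fold lower number from compound 2 to compound 1 (1.99 log units; beyond the scatter). From compound 3 to compound 4 a step of a 54-fold lower number from compound 3 to compound 4 (1.73 log units; beyond the scatter) is expected. For compound 4 the estimated value is 400 nM, with a range from 80 nM to 3000 nM.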

Compound 4, concentration for 50% growth inhibition: 22700 nM
Compound 4: middle estimate off by 57-fold (1.75 log units), on the low side; measured number above the stated range.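

On the second core, methylsulfanyl in place of methoxy gives a 1.0-fold higher number from compound 3 to compound 4 (0.02 log units; within the scatter), so compound 3 and compound 4 cannot be told apart in this assay. Going by these compounds alone, the change therefore does not carry over from the core of compound 1 to the core of compound 4, and setting the two steps side by side shows how far they part: the same change on two cores in this assay, a 98-fold lower number (1.99 log units; beyond the scatter) from compound 2 to compound 1 and a 1.0-fold higher number (0.02 log units; within the scatter) from compound 3 to compound 4, 100-fold (2.01 log units) apart, beyond the scatter of two such steps This shows that the effect of the change depends on the core it sits on, but with only two pairs, it does not show which feature of the core decides the outcome, or which of the two steps a further core would resemble.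

The compounds shown leave open how other groups in the same place, such as an ethoxy group, a chlorine atom or an amine, would behave on each core, and whether the large step is tied to methylsulfanyl alone. They also leave open what the same change would do on a third core.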